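A Difluorophenyl Replaces Pyridin-2-yl on the Shared Core

The source may report more compounds than this note shows. Statements on the series, on what has been measured and on what is new or still open speak of the compounds shown alone.

The measured compounds and their values:
compound 1, `C[C@H](Nc1ncnc2[nH]cnc12)c1nn(-c2cccnc2)c2cc(F)ccc12`: 8%
compound 2, `C[C@H](Nc1ncnc2[nH]cnc12)c1nn(-c2ccccn2)c2cc(F)ccc12`: 7%

In a functional assay on Bel-7402 cells (Homo sapiens) for inhibition, read by sulforhodamine B assay, with a stated time of 72 h, tested at 10 uM (a lower number here means less inhibition, a higher number more inhibition at the concentration tested (going by the name of the read-out)), compound 1 gives 8% and compound 2 gives 7%. Going by the values given here, the two numbers lie within the scatter of each other, so compound 2 stands level with compound 1; the single step, a number 1 percentage points lower from compound 1 to compound 2 (within the scatter), amounts to no change beyond the scatter.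

Compound 3, `C[C@H](Nc1ncnc2[nH]cnc12)c1nn(-c2cc(F)cc(F)c2)c2cc(F)ccc12`, differs from compound 2 by 3,5-difluorophenyl in place of pyridin-2-yl on an aromatic nitrogen. Among the compounds with values here, no measured step involves the incoming 3,5-difluorophenyl; the only step known swaps one pyridyl for another and was within the scatter. With nothing to indicate a shift, the expectation for compound 3 in this assay is a step of a number 3 percentage points higher from compound 2 to compound 3 (within the scatter), that is, none beyond the scatter. Compound 3 is therefore estimated at 10%, with a range from 0% to 30%.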

Compound 3, a percentage reported as inhibition, at one concentration (the size of the read-out at that concentration, not a potency): -8%
The estimate for compound 3 lay 18 percentage points above the measured number, outside the stated range (below it).
By their numbers in this assay, from the lowest: compound 3; then compounds 2 and 1 (each within the scatter of the next).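

In this assay the group on this aromatic nitrogen proves able to move the number: the two pyridyl groups stood level, but 3,5-difluorophenyl gives a number 15 percentage points lower from compound 2 to compound 3 (beyond the scatter) and, set against the other pyridyl, a number 16 percentage points lower from compound 1 to compound 3 (beyond the scatter). Both steps replace a pyridyl ring with a ring of carbon only, and both point toward less inhibition at the concentration tested, with compound 3 at -8%. Nothing available explains this shift.

The compounds shown leave open whether the lower number goes with losing the ring nitrogen or with gaining the fluorine atoms, a question that an unsubstituted phenyl on the same nitrogen could separate. Also open, from the compounds shown here alone, is whether any group here, such as a methoxy or an amine on that ring, would raise the inhibition at all.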